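This account rests on a few compounds, and the source may have more. Where it says the series, first, only, none or still open, it means among the compounds named here.

Three compounds of the series share one core and differ only in the group on a double-bonded chain carbon bound to a double-bonded chain carbon. In a functional assay on CNE-2 cells (Homo sapiens) for antiproliferative activity, read by sulforhodamine B assay, with a stated time of 48 h (a higher number here means a weaker inhibitor, a lower number a stronger inhibitor), compound 1 (`COc1cc(OC)c(C=C(C(=O)/C=C/c2cccc(OC)c2OC)C(=O)/C=C/c2cccc(OC)c2OC)c(OC)c1`) gives 630 nM, compound 2 (`COc1cccc(/C=C/C(=O)C(=Cc2ccc(O)c(F)c2)C(=O)/C=C/c2cccc(OC)c2OC)c1OC`) gives 260 nM and compound 3 (`COc1cc(C=C(C(=O)/C=C/c2cccc(OC)c2OC)C(=O)/C=C/c2cccc(OC)c2OC)cc(Br)c1O`) gives 220 nM. Compound 3 therefore sits at the low end of these numbers, level with compound 2, since a 1.2-fold lower number from compound 2 to compound 3 (0.07 log units; within the scatter) is no real separation. Compound 1 stands apart from both: a 2.9-fold lower number from compound 1 to compound 3 (0.46 log units; beyond the scatter) and a 2.4-fold lower number from compound 1 to compound 2 (0.38 log units; beyond the scatter) are modest steps.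

Compound 4 (`COc1ccc(C=C(C(=O)/C=C/c2cccc(OC)c2OC)C(=O)/C=C/c2cccc(OC)c2OC)cc1O`) changes the same place: 3-hydroxy-4-methoxyphenyl in place of 3-bromo-4-hydroxy-5-methoxyphenyl on a double-bonded chain carbon bound to a double-bonded chain carbon. In words, 3-hydroxy-4-methoxyphenyl enters in place of 3-bromo-4-hydroxy-5-methoxyphenyl.

The closest guide is a 1.2-fold lower number from compound 2 to compound 3 (0.07 log units; within the scatter), an exchange of one hydroxy-bearing group for another that moved this assay by no more than the scatter. The modest steps away from the 2,4,6-trimethoxyphenyl group of compound 1 mark the largest change seen at this place. Within the data shown here, no measured compound carries the entering group, so a small move towards a higher number is expected, probably not beyond the scatter. The expected step is a 1.4-fold higher number from compound 3 to compound 4 (0.13 log units; within the scatter). For compound 4 the estimated value is 300 nM, with an expected range of 130 nM to 700 nM.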

Compound 4, half-maximal inhibitory concentration: 220 nM
For compound 4 the middle estimate is 1.4-fold (0.13 log units) above the measured one, within the range that was stated.
By their numbers in this assay, from the lowest: compounds 3, 4 and 2 (each within the scatter of the next); then compound 1.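

In this assay, 3-hydroxy-4-methoxyphenyl in place of 3-bromo-4-hydroxy-5-methoxyphenyl gives no change at the digits printed from compound 3 to compound 4 (within the scatter), and a 1.2-fold lower number from compound 2 to compound 4 (0.07 log units; within the scatter) places a third hydroxy-bearing group level with the other two, so among these compounds the bromine is not required to reach this level at this place on a double-bonded chain carbon bound to a double-bonded chain carbon. Compound 1 still stands apart, with a 2.9-fold lower number from compound 1 to compound 4 (0.46 log units; beyond the scatter), and among the four compounds it alone has no hydroxy on this group, although a link between the two observations remains only a correlation across these compounds. No measured evidence accounts for the flat response among compound 2, compound 3 and compound 4, or for the separation of compound 1.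

On these data alone, what remains open is whether the hydroxy itself accounts for that separation, since compound 1 also differs from the others in its full 2,4,6-trimethoxyphenyl pattern. A phenyl group carrying an amine or a carboxylic acid on the ring would show whether this flat response extends beyond hydroxy-bearing groups.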